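A few compounds are considered here, and "the series" means these few. Any claim that something is new, unique, unknown or untested is made for them only; others in the source may bear on it.

Within the data shown here, in a functional assay on LNCaP cells (Homo sapiens) for cytotoxicity, read by MTT assay, with a stated time of 24 h (a lower number here means that less compound is needed, a higher number that more compound is needed for the effect), compound 1 (`COc1ccccc1N1CCN(CCN2CCN(c3ccccc3OC)CC2)CC1`) gives 40000 nM as the higher of the two numbers so far, and compound 2 (`Fc1ccccc1N1CCN(CCCN2CCN(c3ccccc3F)CC2)CC1`) gives 10400 nM as the lower one, a gap beyond the usual scatter. Compound 3 (`COc1ccccc1N1CCN(CCN2CCN(c3ccc(F)cc3)CC2)CC1`) carries 4-fluorophenyl in place of 2-methoxyphenyl on an amine nitrogen in a ring. No single-change comparison has been measured yet, and compound 2 at 10400 nM differs from compound 1 in more than one place, so it is only a loose guide. In this assay a modest move to a lower number is expected (a 2.0-fold lower number from compound 1 to compound 3 (0.30 log units; within the scatter)) and it may stay within the scatter. The estimate for compound 3 is 20000 nM within a range of 6000 nM to 60000 nM on the same read-out.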

Compound 3, half-maximal effective concentration: 78700 nM
Compound 3: the middle estimate sits 3.9-fold (0.59 log units) below what was measured; measured number outside the range, above it.
By their numbers in this assay, from the lowest: compound 2; then compounds 1 and 3 (each within the scatter of the next).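

In this assay, putting 4-fluorophenyl in place of 2-methoxyphenyl on the amine nitrogen in the ring gives a 2.0-fold higher number from compound 1 to compound 3 (0.29 log units; within the scatter) as the first single-change comparison, so no clear difference can be read from this swap. The hydrogen-bond acceptor counted in 2-methoxyphenyl leaves with that group, yet the two compounds remain within the scatter of each other. Nothing available explains this result.

As far as these compounds go, whether a phenyl carrying an amine or a carboxylic acid on this nitrogen would give a difference beyond the scatter remains open.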